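The source may hold more compounds than are shown below. What is called first, only, known or untested is meant among the compounds shown, and "the series" means these compounds.

The measured compounds in a functional assay on HT-29 cells (Homo sapiens) for antiproliferative activity, read by MTT assay, with a stated time of 72 h; on this read-out lower numbers stand for stronger inhibition and higher numbers for weaker inhibition:

compound 1, `C=CC(=O)Nc1nc(-c2ccccc2)cs1`, gives 6600 nM.
compound 2, `C=CC(=O)Nc1nc(-c2ccccc2Cl)cs1`, gives 10200 nM.
compound 3, `C=CC(=O)N(Cc1cc(C)no1)c1nc(-c2ccccc2O)cs1`, gives only a limit of the assay, > 30000 nM.

Compound 2 differs from compound 1 by chloro in place of hydrogen on an aromatic carbon. That change gave a 1.5-fold higher number from compound 1 to compound 2 (0.19 log units; within the scatter). Compound 3 carries a different core than compound 1; the difference between the two cores is not broken down here. For compound 3 the assay reports only a limit, (the limit of > 30000 nM in this assay, at which 1 of the 3 values shown sits).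

Compound 4, `C=CC(=O)N(Cc1cc(C)no1)c1nc(-c2ccc(Cl)cc2O)cs1`, has not yet been measured in this assay. It differs from compound 3 by chloro in place of hydrogen on an aromatic carbon. This is the same kind of change as that from compound 1 to compound 2, but the place is not the same: in compound 2 the chloro sits ortho to a large group, whereas in compound 4 it sits meta to a hydroxy group and para to a large group. Since compound 3 gives only a limit, > 30000 nM, and the earlier step of a 1.5-fold higher number from compound 1 to compound 2 (0.19 log units; within the scatter) stayed within the scatter, compound 4 is expected to remain at or beyond the limit. The estimated step is a step that the limit leaves unreadable from compound 3 to compound 4. Compound 4 is therefore estimated at 45000 nM, between 15000 nM and 150000 nM.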

Compound 4, half-maximal inhibitory concentration: > 30000 nM
Compound 4: no number, only a limit (the forecaster's own chance of this, stated with the estimate: 70%); the middle value lies beyond the limit too.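

In this assay compound 3 and compound 4 both give only a limit and no number, so no step can be read for chloro in place of hydrogen between them: the limit of > 30000 nM in this assay, at which 2 of the 4 values shown sit.

The compounds shown leave open how far beyond the limit either compound lies, and whether 4-chloro-2-hydroxyphenyl in place of 2-hydroxyphenyl changes the read-out at all.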